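A few compounds are considered here, and "the series" means these few. Any claim that something is new, unique, unknown or untested is made for them only; others in the source may bear on it.

The set rests on the core of compound 1 `NC1=NS(=O)(=O)c2ccccc21`, a small bicyclic sulfonamide. In a physicochemical assay for solubility (on this read-out higher numbers stand for higher solubility and lower numbers for lower solubility), compound 1 gives 798000 nM. Compound 2 `CCN=S1(=O)NC(=O)c2ccccc21`, an ethyl-bearing relative of the same core, gives in this assay 947000 nM. The two numbers sit within the scatter of each other, so no order between compound 1 and compound 2 is claimed. For compound 3 `CCN1C(=O)c2ccccc2S1(=O)=O` this assay reports no number but a limit, < 13000 nM; it is the limit of < 13000 nM in this assay, at which 1 of the 3 values shown sits.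

Compound 4 `CCNC1=NS(=O)(=O)c2ccccc21` has not been measured. It differs from compound 1 by ethyl in place of hydrogen on an amine nitrogen. Within the data shown here, no pair of measured compounds differs in exactly this way, so no measured step can be borrowed for it. Compound 2 shows that an ethyl group can be present without moving the number away from compound 1 beyond the scatter, while compound 3 shows that an ethyl group elsewhere on the core comes with only a limit. On this footing a moderate decrease is expected from compound 1 to compound 4, a step of about a 2.7-fold lower number from compound 1 to compound 4 (0.42 log units; beyond the scatter) in this assay. The estimate for compound 4 is 300000 nM, with a range from 50000 nM to 900000 nM.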

Compound 4, solubility: 971000 nM
For compound 4 the middle estimate is 3.2-fold (0.51 log units) below the measured one; measured number outside the range, above it.
By their numbers in this assay, from the lowest: compounds 1, 2 and 4 (each within the scatter of the next). At a limit, below all of these: compound 3.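

Ethyl in place of hydrogen on an amine nitrogen now has a measured step of its own (a 1.2-fold higher number from compound 1 to compound 4 (0.09 log units; within the scatter)) in this assay, where the earlier compounds offered no pair that differed in one place. At this position, on a nitrogen whose other neighbour is a carbon with a double bond to nitrogen, the exchange of hydrogen for ethyl therefore stays within the scatter, and this is a single reading for a single pair. Compound 4 carries a number rather than a limit, so ethyl on this amine nitrogen does not by itself bring the shared core to a limit, while compound 3, with its ethyl group elsewhere on the core, remains the only compound at one: the limit of < 13000 nM in this assay, at which 1 of the 4 values shown sits.

Going by these compounds, whether a longer chain such as propyl or butyl, a ring such as phenyl, or a carboxylic acid on the same amine nitrogen would also stay within the scatter of compound 1 remains open. The compounds shown also leave open whether the step for ethyl would read the same on any core other than this one, since it rests on one pair in this assay alone.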